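The compounds below may be only part of what the source reports. "The series", "measured", "known", "first", "only" and "open" are said of these compounds alone.

Measured so far:
compound 1 `CN(C)CCn1cnnc1-c1cc(Oc2ccc(NC(=O)Nc3ccc(Cl)cc3Cl)cc2F)ccn1` — 1890 nM
compound 2 `CCN(CC)CCn1cnnc1-c1cc(Oc2ccc(NC(=O)Nc3ccc(F)c(F)c3)cc2F)ccn1` — 1240 nM

In a functional assay on HT-29 cells (Homo sapiens) for antiproliferative activity, read by MTT assay, with a stated time of 72 h (on this read-out lower numbers stand for stronger inhibition and higher numbers for weaker inhibition), compound 2 gives 1240 nM, and compound 1 gives 1890 nM; the two numbers lie within the scatter of each other, so neither can be set apart from the other. Compound 3 `CCN(CC)CCn1cnnc1-c1cc(Oc2ccc(NC(=O)Nc3ccc(Cl)cc3Cl)cc2F)ccn1` carries 2,4-dichlorophenyl in place of 3,4-difluorophenyl on an amide-type nitrogen. Within the data shown here, no measured pair shows this change alone, so the size of the step is open. Compound 1 already carries the 2,4-dichlorophenyl and gives 1890 nM, which suggests no step beyond the scatter in this assay from compound 2 to compound 3. Compound 3 is therefore expected near 1600 nM, within 700 nM to 3600 nM, an expected step of a 1.3-fold higher number from compound 2 to compound 3 (0.11 log units; within the scatter).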

Compound 3, half-maximal inhibitory concentration: 3590 nM
Compound 3: middle estimate off by 2.2-fold (0.35 log units), on the low side; the range from low to high includes it.
By their numbers in this assay, from the lowest: compounds 2, 1 and 3 (each within the scatter of the next, the first and the last beyond it).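

In this assay, among these compounds, the change to 2,4-dichlorophenyl in place of 3,4-difluorophenyl on the amide-type nitrogen gives the first step beyond the scatter, a modest one: a 2.9-fold higher number from compound 2 to compound 3 (0.46 log units; beyond the scatter). Diethylamino in place of dimethylamino on the chain, with 2,4-dichlorophenyl held fixed, gives a 1.9-fold higher number from compound 1 to compound 3 (0.28 log units; within the scatter), which stays within the scatter. Nothing measured here accounts for either step.

Going by these compounds, whether the aryl step depends on the chlorine atoms or on where they sit remains open, as 3,4-dichlorophenyl would be needed to separate the two. On these data alone, how a morpholine in place of the diethylamino group would read is also open.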